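Pyridin-4-yl for pyridin-3-yl: the step to compound 4

This account rests on a few compounds, and the source may have more. Where it says the series, first, only, none or still open, it means among the compounds named here.

compound 1 `Cc1ccc(-c2ccc(CNCCNc3ccnc4cc(Cl)ccc34)s2)cc1` gives 2300 nM
compound 2 `Clc1ccc2c(NCCNCc3ccc(-c4ccnc(Cl)n4)s3)ccnc2c1` gives 10900 nM
compound 3 `Clc1ccc2c(NCCNCc3ccc(-c4cccnc4)s3)ccnc2c1` gives 16400 nM

All three values come from an ADME assay on HepG2 cells (Homo sapiens) for cytotoxicity, read by MTT assay, with a stated time of 48 h; a lower number here means a stronger inhibitor, a higher number a weaker inhibitor. Compound 3, with 16400 nM, cannot be separated from its nearest neighbour in the series: a 1.5-fold higher number from compound 2 to compound 3 (0.18 log units; within the scatter). Compound 1 stands clearly apart from it: a 7.1-fold higher number from compound 1 to compound 3 (0.85 log units; beyond the scatter).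

Compound 4 `Clc1ccc2c(NCCNCc3ccc(-c4ccncc4)s3)ccnc2c1` has the same atoms as compound 3, joined differently: pyridin-4-yl in place of pyridin-3-yl on an aromatic carbon. Among the measured compounds shown here, no measured step makes this exchange of pyridin-3-yl for pyridin-4-yl, so the evidence is indirect. The closest guide is the step between compound 2 and compound 3, where one group without a 4-methylphenyl ring replaces another and the values stay within the scatter. The larger steps, a 4.7-fold higher number from compound 1 to compound 2 (0.68 log units; beyond the scatter) and a 7.1-fold higher number from compound 1 to compound 3 (0.85 log units; beyond the scatter), both start from 4-methylphenyl, a different kind of replacement, and bear less on this case. In this assay, no step beyond the scatter is therefore expected, and no direction is favoured. The expected result is a 1.1-fold lower number from compound 3 to compound 4 (0.04 log units; within the scatter). The estimate for compound 4 is 15000 nM, with an expected range of 7000 nM to 32000 nM.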

Compound 4, half-maximal inhibitory concentration: 6330 nM
For compound 4 the middle estimate is 2.4-fold (0.37 log units) above the measured one; the whole stated range lies above it.
By their numbers in this assay, from the lowest: compound 1; then compounds 4, 2 and 3 (each within the scatter of the next, the first and the last beyond it).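

In this assay, this place on the five-membered aromatic ring with 1 sulfur distinguishes between two groups with the same atoms and the same counts: pyridin-4-yl in place of pyridin-3-yl gives a 2.6-fold lower number from compound 3 to compound 4 (0.41 log units; beyond the scatter) and so shows that an exchange without 4-methylphenyl can also go beyond the scatter here. The other two steps place pyridin-4-yl differently: 2-chloropyrimidin-4-yl in its place gives no separable difference, with a 1.7-fold lower number from compound 2 to compound 4 (0.24 log units; within the scatter) as the printed step, while 4-methylphenyl remains apart, with a 2.8-fold higher number from compound 1 to compound 4 (0.44 log units; beyond the scatter) as its step, so compound 1 keeps the lowest number of the series. Nothing measured alongside these values accounts for the difference between the two pyridine attachments, and the step stands here as an observation only.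

Open, going by these compounds, is whether pyridin-2-yl would fall with pyridin-4-yl, with pyridin-3-yl, or apart from both, which would show how far the attachment of the pyridine matters at this place. Also open, on these data alone, is whether the step between the two pyridines would persist with a dimethylamino or carboxylic acid group on the pyridine ring, or with a longer chain in the linker of the shared core.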